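Methoxy for methyl on a weak antiproliferative thiourea

The compounds below may be only part of what the source reports. "The series", "measured", "known", "first", "only" and "open" are said of these compounds alone.

Within the data shown here, compound 2 `Cc1ccccc1NC(=S)N1CCc2c(sc(NC(=O)c3ccccc3C(F)(F)F)c2C(N)=O)C1` is the only compound of this set with a number in a functional assay on HeLa cells (Homo sapiens) for antiproliferative activity, with a stated time of 24 h (a higher number here means a weaker inhibitor, a lower number a stronger inhibitor), where compound 2 gives 47000 nM. Compound 1 `COc1ccccc1NC(=S)N1CCc2c(sc(NC(=O)c3ccccc3Cl)c2C(N)=O)C1` gives in this assay only a limit, > 50000 nM. The limit is one of the two values shown, (the limit of > 50000 nM in this assay, at which 1 of the 2 values shown sits). Compound 3 `COc1ccccc1NC(=S)N1CCc2c(sc(NC(=O)c3ccccc3C(F)(F)F)c2C(N)=O)C1` is unmeasured and differs from compound 2 by methoxy in place of methyl on an aromatic carbon. Among the measured compounds shown here, no step between measured compounds exists for this change, so no step beyond the usual scatter is expected from compound 2 to compound 3, a 1.1-fold higher number from compound 2 to compound 3 (0.03 log units; within the scatter). Compound 3 is therefore estimated at 50000 nM in this assay, between 25000 nM and 100000 nM, with a limit likely to be reported.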

Compound 3, half-maximal inhibitory concentration: > 50000 nM
Compound 3: no number, only a limit; the forecaster's own chance of this, stated with the estimate: 50%; the middle value lies on the limit itself.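

Methoxy in place of methyl on this aromatic carbon, ortho to a large group, gives an at least 1.0-fold higher number from compound 2 to compound 3 (0.02 log units; that floor lies within the scatter) in this assay, so this first single-place comparison shows no gain in activity from the change. On these data alone, compound 3 gives only a limit, so the full size of the step stays unknown, and the values now gather at one point: the limit of > 50000 nM in this assay, at which 2 of the 3 values shown sit. The step between compound 1 and compound 3 cannot be read. Open, as far as these compounds go, is whether an amine, a carboxylic acid or a longer chain in place of the methyl would give a number clearly under this limit.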